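Vero cytotoxicity notes: halogen swap on the aryl arm

The source may report more compounds than this note shows. Statements on the series, on what has been measured and on what is new or still open speak of the compounds shown alone.

Measured compounds:
compound 1 `Clc1ccc(-c2nnc(-c3ccc(-n4cccc4)cc3)o2)cc1` — 253000 nM
compound 2 `Cc1ccc(C)n1-c1ccc(C(=O)N/N=C/c2ccc(O)cc2)cc1` — "not determined" (no result reported)

Within the data shown here, compound 1 `Clc1ccc(-c2nnc(-c3ccc(-n4cccc4)cc3)o2)cc1` is the only compound of the set that carries a number in an ADME assay on Vero cells (Chlorocebus sabaeus) for cytotoxicity, read by MTT assay, with a stated time of 72 h; a higher number here means a weaker inhibitor, a lower number a stronger inhibitor; in this assay compound 1 gives 253000 nM. Among the measured compounds shown here, compound 2 `Cc1ccc(C)n1-c1ccc(C(=O)N/N=C/c2ccc(O)cc2)cc1` has no result in this assay, so nothing can be said of how it compares, and no step between two measured compounds is available.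

Compound 3 `Brc1ccccc1-c1nnc(-c2ccc(-n3cccc3)cc2)o1` is not yet measured in this assay. It differs from compound 1 in one place only: 2-bromophenyl in place of 4-chlorophenyl on an aromatic carbon. The change keeps the count of heavy atoms, donors and acceptors and exchanges one halogen-bearing phenyl for another.

For the measured compounds named here, with no measured step to lean on, the expected step from compound 1 to compound 3 in this assay is a 1.2-fold lower number from compound 1 to compound 3 (0.06 log units; within the scatter), that is, none beyond the usual scatter of repeat runs. For compound 3 the estimate in this assay is 220000 nM, with a plausible range of 80000 nM to 550000 nM. A reading reported only as a limit rather than a number is a real possibility for compound 3, given where compound 1 sits.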

Compound 3, half-maximal inhibitory concentration: 258000 nM
Compound 3: the middle estimate sits 1.2-fold (0.07 log units) below what was measured; low and high end bracket the measured number.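

In this assay, among these compounds, the first measured step is a 1.0-fold higher number from compound 1 to compound 3 (0.01 log units; within the scatter), so 2-bromophenyl and 4-chlorophenyl cannot be told apart at this place, on an aromatic carbon of a five-membered aromatic ring with 2 nitrogen and 1 oxygen. This single step exchanges both the halogen and its place on the phenyl ring, so the two differences are not separated, and neither can be read on its own from compound 1 and compound 3. No measurement at hand offers any explanation for this result.

Open, going by these compounds, is whether 4-bromophenyl or 2-chlorophenyl would also read like compound 1 and compound 3, which would show the halogen and its place on the phenyl ring one at a time. Also open, on these data alone, is whether this position tolerates any exchange of the arm, for instance an unsubstituted phenyl or a phenyl bearing an amine or a carboxylic acid, since the two halogen-bearing phenyls cover only a narrow range of groups.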